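Adding a second chlorine to the pendant ring

The compounds below may be only part of what the source reports. "The series", "measured", "known", "first", "only" and "open" are said of these compounds alone.

Compound 1, `N#CC1=C(N)N(c2ccc(S(N)(=O)=O)cc2)C2=C(CCCC2)C1c1ccc(O)cc1`, in a functional assay on Ehrlich cells (Mus musculus) for cytotoxicity, read by trypan blue exclusion, with a stated time of 2 h, tested at 10 ug/mL (a higher number here means a stronger effect of the compound at the concentration tested, a lower number a weaker effect), gives 20%.
Compound 2, `N#CC1=C(N)N(c2ccc(S(N)(=O)=O)cc2)C2=C(CCCC2)C1/C=C/c1ccccc1`, gives 50%.
Compound 3, `N#CC1=C(N)N(c2ccc(S(N)(=O)=O)cc2)C2=C(CCCC2)C1c1ccccc1Cl`, gives 0%.

Compound 3 stands lowest of the three measured numbers. The steps of a number 20 percentage points lower from compound 1 to compound 3 (beyond the scatter) and a number 50 percentage points lower from compound 2 to compound 3 (beyond the scatter) both end at compound 3, and the step of a number 30 percentage points higher from compound 1 to compound 2 (beyond the scatter) shows that this position in the shared core can move the read-out in either direction.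

Compound 4, `N#CC1=C(N)N(c2ccc(S(N)(=O)=O)cc2)C2=C(CCCC2)C1c1ccc(Cl)c(Cl)c1`, differs from compound 3 in one place: 3,4-dichlorophenyl in place of 2-chlorophenyl on a saturated ring carbon. Going by the values given here, no measured step swaps one chlorine-bearing phenyl for another, so the measured steps only show that swapping the group at this position can shift the read-out by modest to large amounts. Since compound 3 sits at the bottom, the step is expected to be small and upward, or none beyond the scatter: a number 15 percentage points higher from compound 3 to compound 4 (beyond the scatter). For compound 4 in this assay the expected value is 15%, within a range of 0% to 40%.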

Compound 4, a percentage reported as activity, at one concentration (the size of the read-out at that concentration, not a potency): 1%
For compound 4 the middle estimate is 14 percentage points above the measured one; measured number inside the range.
By their numbers in this assay, from the lowest: compounds 3 and 4 (each within the scatter of the next); then compound 1; then compound 2.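

In this assay, exchanging 2-chlorophenyl for 3,4-dichlorophenyl on the saturated ring carbon brings no change that can be told from the scatter (a number 1 percentage points higher from compound 3 to compound 4 (within the scatter)). The low read-out of compound 3 is therefore not confined to one chlorine-bearing phenyl group, since the 3,4-dichlorophenyl group also stays well apart from the 2-phenylethenyl group (a number 49 percentage points lower from compound 2 to compound 4 (beyond the scatter)) and the 4-hydroxyphenyl group (a number 19 percentage points lower from compound 1 to compound 4 (beyond the scatter)). Why the two chlorine-bearing groups read so low cannot be said from the information available.

As far as these compounds go, it remains open how a 4-aminophenyl or 4-carboxyphenyl group would read at this position. From the compounds shown here alone, it is also open whether a longer chain than 2-phenylethenyl would keep or lose the higher read-out of compound 2.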